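Swapping the Amide Group of Compound 3

The source may hold more compounds than are shown below. What is called first, only, known or untested is meant among the compounds shown, and "the series" means these compounds.

Values measured in a functional assay on SK-BR-3 cells (Homo sapiens) for inhibition, read by MTT assay; on this read-out lower numbers stand for stronger inhibition of growth and higher numbers for weaker inhibition of growth:
- compound 1 `CC1=C(/C=C/C(C)=C/C=C/C(C)=C\C(=O)Nc2ccc(O)cc2)C(C)(C)CCC1n1ccnc1`: 3890 nM
- compound 2 `CC1=C(/C=C/C(C)=C/C=C/C(C)=C\C(=O)NCc2cccc(F)c2)C(C)(C)CCC1n1ccnc1`: 4240 nM
- compound 3 `CC1=C(/C=C/C(C)=C/C=C/C(C)=C\C(=O)NCc2ccc(O)cc2)C(C)(C)CC=C1c1cncnc1`: 11500 nM

Of these three, compound 3 has the highest number and so shows the weakest inhibition of growth. Its gaps to compound 1 and compound 2 both lie beyond the usual scatter.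

The next molecule, compound 4 `CC1=C(/C=C/C(C)=C/C=C/C(C)=C\C(=O)Nc2ccccc2)C(C)(C)CC=C1c1cncnc1`, keeps the core of compound 3 and changes one group: phenyl in place of 4-hydroxybenzyl on an amide-type nitrogen. In words, this is phenyl in place of 4-hydroxybenzyl on an amide-type nitrogen.

Among the measured compounds shown here, only one measured step bears on this change, and it belongs to a different core. That step is a 1.1-fold higher number from compound 1 to compound 2 (0.04 log units; within the scatter), with 3-fluorobenzyl in place of 4-hydroxyphenyl on an amide-type nitrogen, and it stays within the scatter. This is thin evidence, but it gives no reason to expect a step beyond the scatter in this assay. The expected change is small, a 1.2-fold lower number from compound 3 to compound 4 (0.06 log units; within the scatter), and lies within the scatter. For compound 4 the estimated value is 10000 nM, with an expected range from 4000 nM to 25000 nM.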

Compound 4, concentration for 50% growth inhibition: 31000 nM
Compound 4: the middle estimate sits 3.1-fold (0.49 log units) below what was measured; measured number above the stated range.
By their numbers in this assay, from the lowest: compounds 1 and 2 (each within the scatter of the next); then compound 3; then compound 4.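

On the core of compound 3, the group on the amide nitrogen clearly affects the result in this assay: phenyl in place of 4-hydroxybenzyl gives a 2.7-fold higher number from compound 3 to compound 4 (0.43 log units; beyond the scatter) and so weaker inhibition of growth. Among the compounds shown here, the only earlier step at this position, on a different core, was a 1.1-fold higher number from compound 1 to compound 2 (0.04 log units; within the scatter) and stayed within the scatter, so that step alone did not show that this position could shift the value. Nothing measured here explains the new step.

As far as these compounds go, the new step removes the hydroxy group and shortens benzyl to phenyl together, and it remains open which of these two differences matters. Also open, from the compounds shown here alone, is how a plain benzyl group or a 4-aminophenyl group on the same amide nitrogen of this core would behave in this assay.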